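Swapping One Aromatic Group at the Assay Limit

A few compounds are considered here, and "the series" means these few. Any claim that something is new, unique, unknown or untested is made for them only; others in the source may bear on it.

Two related compounds have been tested in a functional assay on MCF7 cells (Homo sapiens) for antiproliferative activity, read by CCK-8 assay, with a stated time of 24 h; on this read-out higher numbers stand for weaker inhibition and lower numbers for stronger inhibition. Compound 1 `CCN(CC)Cc1ccc2nc(NC(=O)N/N=C(\C)c3cnccn3)sc2c1` gives > 40000 nM, which is a limit and not a number. Compound 2 `CC1CCN(Cc2ccc3nc(NC(=O)N/N=C/c4ccccn4)sc3c2)CC1` gives > 40000 nM, which is also a limit. Compound 2 thus stands at the limit of > 40000 nM in this assay, at which 2 of the 2 values shown sit.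

Compound 3 `C/C(=N\NC(=O)Nc1nc2ccc(CN3CCC(C)CC3)cc2s1)c1cnccn1` has not yet been measured. It differs from compound 2 by one change, on an amide-type nitrogen: a group of 9 heavy atoms (6 carbon, 3 nitrogen; one six-membered aromatic ring with 2 hetero atoms) in place of a group of 8 heavy atoms (6 carbon, 2 nitrogen; one six-membered aromatic ring with 1 hetero atom), on an amide-type nitrogen. Going by the values given here, no measured pair of compounds shows what a change of this kind does. In this assay, a step no larger than the scatter is therefore expected, with neither direction favoured. The expected step is a number no higher from compound 2 to compound 3 (the limit leaves the size open). Compound 3 is estimated at 40000 nM, with an expected range of 20000 nM to 80000 nM.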

Compound 3, half-maximal inhibitory concentration: 11800 nM
The estimate for compound 3 lay 3.4-fold (0.53 log units) above the measured number; measured number below the stated range.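

Going by these compounds alone, the first measurable number shows that both places can matter in this assay. On the amide-type nitrogen, the group with a six-membered aromatic ring with 2 hetero atoms, in place of the group with a ring with 1 hetero atom, gives an at least 3.3-fold lower number from compound 2 to compound 3 (0.53 log units; beyond the scatter), and with that same group in both compounds, 4-methylpiperidin-1-yl in place of diethylamino gives an at least 3.3-fold lower number from compound 1 to compound 3 (0.53 log units; beyond the scatter). The full size of each step stays open because each starts from a limit and not from a number: the limit of > 40000 nM in this assay, at which 2 of the 3 values shown sit.

Compound 1 and compound 2 differ in more than one place, so these compounds do not show how the two changes compare with each other. Going by these compounds, whether a plain phenyl ring on the amide-type nitrogen, or morpholin-4-yl in place of 4-methylpiperidin-1-yl, would give a lower number also remains open.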